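Benzoyl for carbamoyl on the shared core: expected growth inhibition

The source may hold more compounds than are shown below. What is called first, only, known or untested is meant among the compounds shown, and "the series" means these compounds.

Two compounds in this series carry measured numbers in a functional assay on Malme-3M cells (Homo sapiens) for inhibition, read by sulforhodamine B assay, with a stated time of 48 h; a lower number here means a stronger inhibitor of growth, a higher number a weaker inhibitor of growth. Compound 1 `N#C/C(=C\N1CCN(C(=O)c2ccco2)C1=S)C(=O)Nc1ccc(Cl)cc1` gives 21400 nM there. Compound 2 `N#C/C(=C\N1CCN(C(=O)c2ccco2)C1=S)C(N)=O` gives 12500 nM in this assay, the lowest of the two numbers, with compound 1 as its nearest neighbour. Going by the values given here, the only measured step, a 1.7-fold lower number from compound 1 to compound 2 (0.23 log units; within the scatter), changes the substituent on the amide-type nitrogen and stays within the scatter.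

Compound 3 `N#C/C(=C\N1CCN(C(=O)c2ccco2)C1=S)C(=O)c1ccccc1` is not yet measured in this assay. It differs from compound 2 by phenyl in place of amino on a carbonyl carbon. Among the compounds with values here, the one measured step touches the same carbamoyl group, but from the other side, at the nitrogen rather than the carbonyl carbon, and it was itself within the scatter. Within the data shown here, no measured step tells what a phenyl on the carbonyl carbon does. Given that a change at the neighbouring amide nitrogen gave a 1.7-fold lower number from compound 1 to compound 2 (0.23 log units; within the scatter), no step beyond the scatter is expected in this assay for compound 3, a 1.1-fold higher number from compound 2 to compound 3 (0.05 log units; within the scatter), with a wide range to cover the untested change. Compound 3 is therefore estimated at 14000 nM in this assay, between 4000 nM and 50000 nM.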

Compound 3, concentration for 50% growth inhibition: 30700 nM
For compound 3 the middle estimate is 2.2-fold (0.34 log units) below the measured one, within the range that was stated.
By their numbers in this assay, from the lowest: compounds 2, 1 and 3 (each within the scatter of the next, the first and the last beyond it).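

In this assay, going by these compounds alone, the substituent on the carbonyl carbon now gives the only step that lies beyond the scatter: phenyl in place of amino is a 2.5-fold higher number from compound 2 to compound 3 (0.39 log units; beyond the scatter), a modest step. The same position does not give a separation from every compound, since phenyl in place of (4-chlorophenyl)amino on that carbon is a 1.4-fold higher number from compound 1 to compound 3 (0.16 log units; within the scatter), which lies within the scatter, so the change can be read only against the unsubstituted carbamoyl of compound 2. No measurement accompanies these numbers that could explain the step, so the data link it to the change of group but give no reason for it.

Open, going by these compounds, is how a methyl, a methoxy or a dimethylamino on this carbonyl carbon would compare in this assay, which would show whether compound 2 or compound 3 is the better reference for small groups at this position. Also open, on these data alone, is whether a 4-chlorophenyl placed directly on the carbonyl carbon would stay within the scatter of compound 3, and whether the modest step holds on other cores or in other cell lines.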